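Methoxy in Place of Amino on the Aromatic Carbon

The source may hold more compounds than are shown below. What is called first, only, known or untested is meant among the compounds shown, and "the series" means these compounds.

Three compounds with one shared core were tested in an assay on isolated protein for inhibition of Ca2+/calmodulin-dependent protein kinase II (CaM kinase II) (Rattus norvegicus), tested at 30 uM; a lower number here means less inhibition, a higher number more inhibition at the concentration tested (going by the name of the read-out). Compound 1 `Cn1cnc2c(SCc3ccc(F)cc3)ncnc21` gives 5%. Compound 2 `Fc1ccc(Cn2cnc3ncnc(Cl)c32)cc1` gives 8%, and compound 3 `Nc1ncnc2ncn(Cc3ccc(F)cc3)c12` gives 8%. Compound 3 stands level with compound 2, the pair being the highest of the three numbers, and compound 1 lies within the scatter of both. Among the measured compounds shown here, the one step between neighbours, no change at the digits printed from compound 2 to compound 3 (within the scatter), brought no change. Compound 4 `COc1ncnc2ncn(Cc3ccc(F)cc3)c12` differs from compound 3 by methoxy in place of amino on an aromatic carbon. That earlier exchange at the same aromatic carbon bears on this one and was flat, so a step of a number 1 percentage points lower from compound 3 to compound 4 (within the scatter) is expected, with no movement beyond the scatter. Compound 4 is therefore estimated at 7%, between 0% and 17%.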

Compound 4, a percentage reported as inhibition, at one concentration (the size of the read-out at that concentration, not a potency): 2%
Compound 4: middle estimate off by 5 percentage points, on the high side, within the range that was stated.
By their numbers in this assay, from the lowest: compounds 4, 1, 2 and 3 (each within the scatter of the next).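

In this assay, a third group on this aromatic carbon also stays within the scatter: methoxy in place of amino gives a number 6 percentage points lower from compound 3 to compound 4 (within the scatter), and methoxy in place of chloro gives a number 6 percentage points lower from compound 2 to compound 4 (within the scatter). Amino, chloro and methoxy therefore cannot be told apart at this position, and exchanging amino for methoxy removes its hydrogen-bond donor without a step beyond the scatter. No measurement on hand bears on the reason for these numbers.

Going by these compounds, whether any group on this carbon can move the number beyond the scatter remains open. A carboxylic acid or a longer chain such as butoxy could test this.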